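Dichlorophenyl in Place of Isopropylphenyl on the Saturated Carbon

The source may report more compounds than this note shows. Statements on the series, on what has been measured and on what is new or still open speak of the compounds shown alone.

Compound 2 `CC(C)c1cccc(C2CNCC2C(=O)Nc2cc3cc[nH]c(=O)c3cc2Cl)c1` holds the lowest of the two numbers recorded so far in an assay on isolated protein for inhibition of Rho-associated protein kinase 2 (Homo sapiens), read by a luciferase reporter (on this read-out higher numbers stand for weaker inhibition and lower numbers for stronger inhibition), where compound 2 gives 6 nM. Its nearest neighbour is compound 1 `O=C(Nc1cc2cc[nH]c(=O)c2cc1Cl)C1CNCC1c1ccc(F)cc1`, and in this assay compound 1 gives 9 nM; the two values lie within the scatter of each other, so no order between them is claimed. Among the compounds with values here, the only measured step, a 1.5-fold lower number from compound 1 to compound 2 (0.18 log units; within the scatter), concerns the same saturated ring carbon and stayed within the scatter.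

Compound 3 `O=C(Nc1cc2cc[nH]c(=O)c2cc1Cl)C1CNCC1c1ccc(Cl)cc1Cl` has not yet been measured in this assay. It differs from compound 2 in one place: 2,4-dichlorophenyl in place of 3-isopropylphenyl on a saturated ring carbon. Within the data shown here, the single step that bears on this change, a 1.5-fold lower number from compound 1 to compound 2 (0.18 log units; within the scatter), exchanged one aromatic ring for another on the saturated ring carbon and moved the number by an amount within the scatter; a 2,4-dichlorophenyl has not been tried, so the information is thin. On that basis compound 3 is expected to stay close to compound 2, with an estimated step of a 1.3-fold higher number from compound 2 to compound 3 (0.12 log units; within the scatter), nothing beyond the scatter. The estimate for compound 3 is 8 nM, with a range from 3 nM to 25 nM.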

Compound 3, half-maximal inhibitory concentration: 8 nM
Estimate against measurement, compound 3: no gap at the digits printed; measured number inside the range.
By their numbers in this assay, from the lowest: compounds 2, 3 and 1 (each within the scatter of the next).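

In this assay, the change to 2,4-dichlorophenyl gives a 1.3-fold higher number from compound 2 to compound 3 (0.12 log units; within the scatter), and the comparison with the fluorinated parent gives a 1.1-fold lower number from compound 1 to compound 3 (0.05 log units; within the scatter), so both new steps stay within the scatter. With the earlier step, all three pairs among compounds 1, 2 and 3 now lie within the scatter of one another, and none of the three goes against this: at this saturated ring carbon, two ring chlorines, a single ring fluorine and a 3-isopropylphenyl group all leave the number in one narrow band, which one earlier pair alone could not show. The data shown offer no measurement that accounts for this likeness among the three aromatic groups.

Going by these compounds, the three compounds all carry a six-membered aromatic ring of carbon only at this position, so it remains open whether a cyclohexyl ring in its place, or a carboxylic acid or aminomethyl group on the aromatic ring, would keep the number in the same band. On these data alone, it also remains open how a 4-chlorophenyl or a 2-chlorophenyl group, each with one chlorine, would compare with compound 3.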